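The source may hold more compounds than are shown below. What is called first, only, known or untested is meant among the compounds shown, and "the series" means these compounds.

The measured compounds:
- compound 1, `Nc1ccccc1NC(=O)c1ccc(CSc2nccc(C(F)(F)F)n2)cc1`, in a functional assay on HCT-116 cells (Homo sapiens) for antiproliferative activity, read by CCK-8 assay, with a stated time of 72 h (on this read-out higher numbers stand for weaker inhibition and lower numbers for stronger inhibition), compound 1 gives 1140 nM
- compound 2, `COc1ccc(SCc2ccc(C(=O)Nc3ccccc3N)cc2)cc1`, in this assay compound 2 gives 1640 nM
- compound 3, `CC(C)(C)c1ccc(SCc2ccc(/C=C/C(=O)Nc3ccccc3N)cc2)cc1`, in this assay compound 3 stands as "not determined" (no result reported), so no result was reported for it

Among the two numbers in hand, compound 2 carries the higher one, but its nearest neighbour, compound 1, lies within the usual scatter of the measurement, so the two cannot be told apart on these data. Compound 3 adds nothing to the comparison, since its value in this assay is not available.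

Compound 4, `Cc1cc(C)cc(SCc2ccc(C(=O)Nc3ccccc3N)cc2)c1`, is the next compound to be measured. It differs from compound 2 in one respect: 3,5-dimethylphenyl in place of 4-methoxyphenyl on a sulfur. Among the measured compounds shown here, no measured pair in this set shows what such a change does, so there is no step on which to base a direction.

Compound 4 is therefore expected to fall close to compound 2, with a step of a 1.2-fold lower number from compound 2 to compound 4 (0.07 log units; within the scatter) that is estimated to stay within the scatter. For compound 4 the estimate in this assay is 1400 nM, expected between 500 nM and 4000 nM.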

Compound 4, half-maximal inhibitory concentration: 2490 nM
For compound 4 the middle estimate is 1.8-fold (0.25 log units) below the measured one; the measured number falls inside the stated range.
By their numbers in this assay, from the lowest: compounds 1, 2 and 4 (each within the scatter of the next, the first and the last beyond it).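

In this assay, the first step read at this position, 3,5-dimethylphenyl in place of 4-methoxyphenyl on a sulfur, gives (a 1.5-fold higher number from compound 2 to compound 4 (0.18 log units; within the scatter)), so the two compounds cannot be told apart. The number of heavy atoms stays the same across this change, while the hydrogen-bond acceptor of the 4-methoxyphenyl group is absent from the 3,5-dimethylphenyl group, and on this single pair that exchange produces no difference beyond the scatter. Nothing at hand bears on the reason for this result.

The compounds shown leave open whether an amine or a carboxylic acid on this aromatic ring would carry the number beyond the scatter, and whether a longer chain on the sulfur in place of the ring would do so. They also leave open what an oxygen in place of the sulfur would do.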